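A few compounds are considered here, and "the series" means these few. Any claim that something is new, unique, unknown or untested is made for them only; others in the source may bear on it.

Measured compounds:
compound 1, `Cc1ccnc(OC(c2ccc(C(F)(F)F)cc2)C2CCN(C(C)CCNC(=O)c3c(Cl)cncc3Cl)CC2)c1`, 33600 nM
compound 2, `CC(CCNC(=O)c1c(Cl)cncc1Cl)N1CCC(C(Oc2ncccc2Cl)c2ccc(C(F)(F)F)cc2)CC1`, 16700 nM
compound 3, `CC(CCNC(=O)c1c(Cl)cncc1Cl)N1CCC(C(Oc2ccccc2C(F)(F)F)c2ccc(C(F)(F)F)cc2)CC1`, 12500 nM

The three compounds share one core and differ only in the aromatic group on the oxygen on a saturated carbon. In an ADME assay on PBMC cells (Homo sapiens) for cytotoxicity (a higher number here means that more compound is tolerated, a lower number that less compound is tolerated), compound 3 gives the lowest of the three numbers; its nearest neighbour is compound 2, at a distance within the scatter, while the distance to compound 1 is beyond the scatter, though modest.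

Compound 4, `CC(CCNC(=O)c1c(Cl)cncc1Cl)N1CCC(C(Oc2ccccc2)c2ccc(C(F)(F)F)cc2)CC1`, has not yet been measured. It differs from compound 3 in one place: hydrogen in place of trifluoromethyl on an aromatic carbon.

Among the measured compounds shown here, the steps that bear on this change are those at the same aromatic group: a 2.0-fold lower number from compound 1 to compound 2 (0.30 log units; within the scatter), a 2.7-fold lower number from compound 1 to compound 3 (0.43 log units; beyond the scatter) and a 1.3-fold lower number from compound 2 to compound 3 (0.13 log units; within the scatter). All three are small, and swapping one aromatic group for another has moved this assay by no more than a modest amount. Removing the trifluoromethyl from the phenyl is a smaller change than any of those swaps, so compound 4 is expected to give 17000 nM, with a range from 8000 nM to 35000 nM; the expected step of a 1.4-fold higher number from compound 3 to compound 4 (0.13 log units; within the scatter) is estimated to lie within the scatter, if anything towards a slightly higher number.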

Compound 4, half-maximal cytotoxic concentration: 6800 nM
For compound 4 the middle estimate is 2.5-fold (0.40 log units) above the measured one; the whole stated range lies above it.
By their numbers in this assay, from the lowest: compounds 4, 3, 2 and 1 (each within the scatter of the next, the first and the last beyond it).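

In this assay, hydrogen in place of trifluoromethyl gives a 1.8-fold lower number from compound 3 to compound 4 (0.26 log units; within the scatter) and so stays within the scatter, which shows that this aromatic carbon can lose the trifluoromethyl without a clear shift in the number. The unsubstituted phenyl does separate from both pyridine-bearing compounds, however: there is a 2.5-fold lower number from compound 2 to compound 4 (0.39 log units; beyond the scatter) and also a 4.9-fold lower number from compound 1 to compound 4 (0.69 log units; beyond the scatter) as the widest step in the set, whereas compound 3 stood beyond the scatter only from compound 1. Nothing available accounts for these steps.

From the compounds shown here alone, it remains open whether a nitrile, a methoxy group or an amine on that same aromatic carbon would stay close to compound 4 or move towards compound 1. The compounds also leave open whether an unsubstituted pyridin-2-yl on the oxygen would group with the phenyl compounds or with the substituted pyridines.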